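This account rests on a few compounds, and the source may have more. Where it says the series, first, only, none or still open, it means among the compounds named here.

Measured compounds:
- compound 1 `N#Cc1ccc(NC(=O)c2ccc3cccnc3c2O)c(Cl)c1`: 3670 nM
- compound 2 `O=C(Nc1ccc(C(F)(F)F)cc1)c1cc(Cl)ccc1O`: 740 nM
- compound 3 `Cc1cccc(O)c1C(=O)Nc1ccc(C#N)cc1`: 7940 nM

In a functional assay on KG-1 cells (Homo sapiens) for cytotoxicity, read by luminescence and CellTiter-Glo, with a stated time of 3 days (a lower number here means a stronger inhibitor, a higher number a weaker inhibitor), compound 1 gives 3670 nM, which places it second highest among the three numbers. Its nearest neighbour is compound 3, whose value in this assay is 7940 nM, a gap that lies beyond the scatter. The furthest is compound 2, which in this assay gives 740 nM, the lowest of the three, again beyond the scatter from compound 1.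

Compound 4 `N#Cc1ccc(NC(=O)c2ccc3cccnc3c2O)c(F)c1` has not yet been measured. It differs from compound 1 in one place: fluoro in place of chloro on an aromatic carbon. The group that leaves and the group that enters each bring one heavy atom, with no ring, no hydrogen-bond donors or acceptors and no net charge. Going by the values given here, no pair of measured compounds here differs in this single way, so the step has no precedent among them.

From this, the account expects only a modest step in this assay from compound 1 to compound 4, leaning toward a slightly higher number, though a result within the scatter would not surprise. For compound 4 the estimate in this assay is 4800 nM, with a range from 1900 nM to 12000 nM, which corresponds to an expected step of a 1.3-fold higher number from compound 1 to compound 4 (0.12 log units; within the scatter).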

Compound 4, half-maximal inhibitory concentration: 3260 nM
Beside the measured number, compound 4's estimate is 1.5-fold (0.17 log units) above it; measured number inside the range.
By their numbers in this assay, from the lowest: compound 2; then compounds 4 and 1 (each within the scatter of the next); then compound 3.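

In this assay, fluoro in place of chloro on this aromatic carbon, ortho to a large group and meta to a cyano group, gives a 1.1-fold lower number from compound 1 to compound 4 (0.05 log units; within the scatter), so on this read-out the two halogens cannot be told apart at this position. Going by these compounds alone, the earlier compounds could not show this, since none of them forms a pair differing in one place, and this is the only such step available here. Nothing measured here speaks to the reason for this result.

The compounds shown leave open whether an amine, a methoxy group or plain hydrogen on this same aromatic carbon would give a number apart from those of the two halogens. They also leave open whether the same exchange of chloro for fluoro would read alike at any other place on the core of compound 1.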